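Cytotoxicity of azido and triazole coumarins on MRC5 cells

The compounds below may be only part of what the source reports. "The series", "measured", "known", "first", "only" and "open" are said of these compounds alone.

Measured compounds:
- compound 1, `NCCC(=O)N1Cc2ccccc2-c2nnn(-c3cc4cc(Br)ccc4oc3=O)c2-c2ccccc21`: 100000 nM
- compound 2, `[N-]=[N+]=Nc1cc2cc(Br)ccc2oc1=O`: 70400 nM
- compound 3, `NCCC(=O)N1Cc2ccccc2-c2nnn(-c3cc4ccccc4oc3=O)c2-c2ccccc21`: 110000 nM

The account concerns cytotoxicity measured in a toxicity assay on MRC5 cells (Homo sapiens) for cytotoxicity, read by MTT assay, with a stated time of 24 h; on this read-out higher numbers stand for weaker inhibition and lower numbers for stronger inhibition. Compound 1 gives 100000 nM in this assay, and compound 3 gives 110000 nM. The two differ by the change (hydrogen in place of bromo on an aromatic carbon), and the step of a 1.1-fold higher number from compound 1 to compound 3 (0.04 log units; within the scatter) is small. Compound 2 gives 70400 nM; its gaps to compound 1 and to compound 3 both lie within the scatter, so no order among the three can be read. How the core of compound 2 differs from the core of compound 1 is not broken down here.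

Compound 4, `[N-]=[N+]=Nc1cc2ccccc2oc1=O`, has not been measured. It differs from compound 2 by the change (hydrogen in place of bromo on an aromatic carbon). The place lines for this change and for the change from compound 1 to compound 3 read the same word for word, so it is the same kind of change made on two different cores. Because the step of a 1.1-fold higher number from compound 1 to compound 3 (0.04 log units; within the scatter) was within the scatter, a step of similar small size, a 1.1-fold higher number from compound 2 to compound 4 (0.04 log units; within the scatter), is expected from compound 2 to compound 4 in this assay. Compound 4 is therefore estimated to give 78000 nM in this assay, with a range expected from 35000 nM to 160000 nM. This rests on a single measured pair, so the expectation is loose.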

Compound 4, half-maximal inhibitory concentration: 70200 nM
Beside the measured number, compound 4's estimate is 1.1-fold (0.05 log units) above it; the range from low to high includes it.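

In this assay, hydrogen in place of bromo on the aromatic carbon gives a 1.0-fold lower number from compound 2 to compound 4 (0.00 log units; within the scatter), so on this core, as on the core of compound 1, the change leaves no readable mark on the number. Set beside each other, the two steps do not differ: the same change on two cores in this assay, a 1.1-fold higher number (0.04 log units; within the scatter) from compound 1 to compound 3 and a 1.0-fold lower number (0.00 log units; within the scatter) from compound 2 to compound 4, 1.1-fold (0.04 log units) apart, within the scatter of two such steps. This shows that the small size of the step carried over from one core to the other in this pair of pairs, but with neither step beyond the scatter, it does not show that a measurable effect of the change would carry over, and two pairs in one assay on one cell line cannot establish a rule for the series.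

The compounds shown leave open whether another group at the same aromatic carbon, such as methoxy, nitrile or a carboxylic acid, would move the number on either core. They also leave open whether a longer chain in place of the one ending in an amine on compound 1 and compound 3 would change the picture, and whether the bromo-to-hydrogen change would stay as small on such a compound.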